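Chlorophenyl position swap within a shared core

A few compounds are considered here, and "the series" means these few. Any claim that something is new, unique, unknown or untested is made for them only; others in the source may bear on it.

Compound 1 `CN(C)CCCNc1nc(-c2ccc(NC(=O)Nc3ccc(Cl)cc3)cc2)nc2c(Cl)c(Cl)sc12` gives 1160 nM in a functional assay on MDA-MB-231 cells (Homo sapiens) for cytotoxicity, read by MTT assay, with a stated time of 72 h; on this read-out higher numbers stand for weaker inhibition and lower numbers for stronger inhibition. Compound 2 `CN(C)CCCNc1nc(-c2ccc(NC(=O)Nc3ccccc3Cl)cc2)nc2c(Cl)c(Cl)sc12` carries the change (2-chlorophenyl in place of 4-chlorophenyl on an amide-type nitrogen), and in this assay compound 2 gives 1560 nM; the measured step is a 1.3-fold higher number from compound 1 to compound 2 (0.13 log units; within the scatter). Compound 3 `CCN(CC)CCNc1nc(-c2ccc(NC(=O)Nc3ccc(Cl)cc3)cc2)nc2c(Cl)c(Cl)sc12` differs from compound 1 in its side chain, (diethylamino in place of (dimethylamino)methyl on a saturated chain carbon, two bonds along the chain from a nitrogen on an aromatic ring), and in this assay compound 3 gives 750 nM; the step is a 1.5-fold lower number from compound 1 to compound 3 (0.19 log units; within the scatter). Compound 4 `CCN(CC)CCNc1nc(-c2ccc(NC(=O)Nc3ccccc3Cl)cc2)nc2c(Cl)c(Cl)sc12` is not yet measured. It differs from compound 3 by 2-chlorophenyl in place of 4-chlorophenyl on an amide-type nitrogen, the same change already seen once, at a place described in identical words. Within the data shown here, only one prior instance exists, so the expectation rests on that single step. The expected step for compound 4 is a 1.3-fold higher number from compound 3 to compound 4 (0.12 log units; within the scatter), resting on a 1.3-fold higher number from compound 1 to compound 2 (0.13 log units; within the scatter). Compound 4 is therefore estimated at 1000 nM, with a range from 500 nM to 2000 nM.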

Compound 4, half-maximal inhibitory concentration: 1410 nM
Compound 4: the middle estimate sits 1.4-fold (0.15 log units) below what was measured; measured number inside the range.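

In this assay, 2-chlorophenyl in place of 4-chlorophenyl gives a 1.9-fold higher number from compound 3 to compound 4 (0.27 log units; within the scatter), and this step agrees with its earlier instance: the same change on two cores in this assay, a 1.3-fold higher number (0.13 log units; within the scatter) from compound 1 to compound 2 and a 1.9-fold higher number (0.27 log units; within the scatter) from compound 3 to compound 4, 1.4-fold (0.15 log units) apart, within the scatter of two such steps. The side-chain change, read with 2-chlorophenyl in place, gives a 1.1-fold lower number from compound 2 to compound 4 (0.04 log units; within the scatter), and it also agrees with its earlier instance: the same change on two cores in this assay, a 1.5-fold lower number (0.19 log units; within the scatter) from compound 1 to compound 3 and a 1.1-fold lower number (0.04 log units; within the scatter) from compound 2 to compound 4, 1.4-fold (0.15 log units) apart, within the scatter of two such steps. Each change therefore carries between these compounds without a detectable difference, but with every step within the scatter, this does not show that either change has a real effect, and two instances set no rule for other cores.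

Still open, as far as these compounds go, is how unsubstituted phenyl or 2-fluorophenyl on the amide-type nitrogen would read. Also open, from the compounds shown here alone, is whether a piperidine or a longer chain in place of diethylamino would give a step beyond the scatter.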